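Aryl hydrazide to diacylhydrazide: an untested step

A few compounds are considered here, and "the series" means these few. Any claim that something is new, unique, unknown or untested is made for them only; others in the source may bear on it.

Measured compounds in a functional assay on MDA-MB-231 cells (Homo sapiens) for antiproliferative activity, read by MTT assay, with a stated time of 24 h; on this read-out higher numbers stand for weaker inhibition and lower numbers for stronger inhibition:
compound 1 `O=C(NNc1ccccc1Cl)c1cccc(NS(=O)(=O)c2cnc(O)nc2O)c1`, 2090 nM
compound 2 `O=C(NNc1ccccc1Cl)c1ccccc1NS(=O)(=O)c1cnc(O)nc1O`, 18900 nM
compound 3 `Cc1ccccc1C(=O)NNC(=O)c1ccc(NS(=O)(=O)c2cnc(O)nc2O)cc1`, 7040 nM

Compound 1 gives the lowest number of the three in this assay, with 2090 nM. Compound 3, at 7040 nM, is the nearest to it, and that gap already lies beyond the scatter; compound 2, at 18900 nM, is the furthest away, also beyond the scatter. No pair among these three differs in only one place, so no single step can be read off between them.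

Compound 4 `O=C(NNC(=O)c1cccc(NS(=O)(=O)c2cnc(O)nc2O)c1)c1ccc(F)cc1` is not yet measured. It departs from compound 1 in one place: (4-fluorophenyl)carbonyl in place of 2-chlorophenyl on an amine nitrogen. With this change compound 4 carries the same kind of hydrazide linkage as compound 3, while keeping the arrangement of the shared core seen in compound 1. Because compound 3 gives 7040 nM, a number above that of compound 1, the expectation for compound 4 is a modest move towards weaker inhibition, a 2.2-fold higher number from compound 1 to compound 4 (0.33 log units; beyond the scatter), though a step within the scatter would not be surprising. Compound 4 is estimated at 4500 nM, with a range from 1500 nM to 14000 nM.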

Compound 4, half-maximal inhibitory concentration: > 20000 nM
Compound 4 was reported as a limit; the forecaster's own chance of this, stated with the estimate: 5%; middle value at least 4.4-fold (0.64 log units) from the limit.
By their numbers in this assay, from the lowest: compound 1; then compound 3; then compound 2. At a limit, above all of these: compound 4.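

In this assay, among the compounds shown here, the exchange of 2-chlorophenyl for (4-fluorophenyl)carbonyl on an amine nitrogen whose other neighbour is an amide-type nitrogen gives an at least 9.5-fold higher number from compound 1 to compound 4 (0.98 log units; beyond the scatter), the first step that can be read at a single place. For compound 4 the reported > 20000 nM is a limit of the assay and not a number. The earlier compounds shown here offered no such pair, and this step shows that the group on this nitrogen matters to the read-out, although its full size is fixed from one side only: the limit of > 20000 nM in this assay, at which 1 of the 4 values shown sits.

Going by these compounds, what stays open is which part of the change carries the step, the added carbonyl, the fluorine in place of the chlorine, or the altered substitution on the aromatic ring, all of which arrive together in this single exchange. On these data alone, it also remains unknown how this nitrogen would respond to (2-chlorophenyl)carbonyl, to an unsubstituted phenyl, or to an acetyl group or a longer alkyl chain, any of which could separate these contributions.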